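Fluorine for methyl on the aryl imidazopyridine

The source may hold more compounds than are shown below. What is called first, only, known or untested is meant among the compounds shown, and "the series" means these compounds.

Measured compounds:
Compound 1 `CC#CC(CC(=O)O)c1ccc(OCc2ccn3cc(-c4ccc(C)cc4C)nc3c2)cc1` gives 503 nM in an assay on isolated protein for agonist activity at Free fatty acid receptor 1 (Homo sapiens); on this read-out lower numbers stand for an effect already at smaller amounts and higher numbers for an effect only at larger amounts of compound.
Compound 2 `CC#CC(CC(=O)O)c1ccc(OCc2ccc3nc(-c4ccccc4C)cn3c2)cc1` gives 389 nM in this assay.

For the measured compounds named here, only two compounds have been measured, and their two values sit within the usual scatter of one another, so compound 1 cannot be placed ahead of or behind compound 2 on this assay; the two are, on present data, indistinguishable. Going by the values given here, no single-point step between measured compounds is available, so nothing is yet known about how changes on the aryl group attached to the shared core of compound 1 move the read-out.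

Compound 3 `CC#CC(CC(=O)O)c1ccc(OCc2ccn3cc(-c4cc(F)ccc4F)nc3c2)cc1` is the next compound. It differs from compound 1 in one place: 2,5-difluorophenyl in place of 2,4-dimethylphenyl on an aromatic carbon. Among the compounds with values here, with no measured step to lean on, the only guide is that both measured compounds, carrying methyl-substituted phenyl groups, land in the same region of this assay. The step is therefore expected to be small, without a clear direction, and most likely not beyond the scatter. For compound 3 the expectation is 600 nM, within a range of 200 nM to 1800 nM, which means an estimated step of a 1.2-fold higher number from compound 1 to compound 3 (0.08 log units; within the scatter).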

Compound 3, half-maximal effective concentration: 639 nM
Compound 3: middle estimate off by 1.1-fold (0.03 log units), on the low side; measured number inside the range.
By their numbers in this assay, from the lowest: compounds 2, 1 and 3 (each within the scatter of the next).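

In this assay, putting 2,5-difluorophenyl in place of 2,4-dimethylphenyl on this aromatic carbon of the five-membered ring gives a 1.3-fold higher number from compound 1 to compound 3 (0.10 log units; within the scatter), the first step measured at this position. The exchange replaces both methyl groups with fluorine and alters the substitution pattern on the phenyl ring, yet the read-out does not distinguish the two groups, so this position accepts this particular change without a shift that can be told from the scatter. No measured evidence here speaks to why the two aryl groups read alike.

Because both methyl groups and their pattern change in a single step, the part played by each substituent remains unresolved, and a mixed group such as 2-fluoro-4-methylphenyl would be needed to separate them. On these data alone, it also remains open whether any group at this carbon can move the number beyond the scatter, for instance an unsubstituted phenyl, a pyridine ring, a morpholine or a phenyl carrying a trifluoromethyl group.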